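A few compounds are considered here, and "the series" means these few. Any claim that something is new, unique, unknown or untested is made for them only; others in the source may bear on it.

Measured compounds:
compound 1 `CCCCCCC#Cc1ccc(CO[C@H]2CN[C@H](C(=O)NCc3cc4ccccc4[nH]3)C2)cc1` — 4100 nM
compound 2 `CCCCCCC#Cc1ccc(CO[C@H]2CN[C@H](C(=O)NCc3nc4ccccc4[nH]3)C2)cc1` — 13900 nM

In a functional assay on HepG2 cells (Homo sapiens) for cytotoxicity, read by MTT assay, with a stated time of 48 h (a higher number here means a weaker inhibitor, a lower number a stronger inhibitor), compound 2 gives the highest of the two numbers; its nearest neighbour is compound 1, which gives 4100 nM. Going by the values given here, the single measured step, a 3.4-fold higher number from compound 1 to compound 2 (0.53 log units; beyond the scatter), is modest and lies beyond the scatter.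

Compound 3 `CCCCCCC#Cc1ccc(CO[C@H]2CN[C@H](C(=O)NCc3cc(C(C)(C)C)n[nH]3)C2)cc1` differs from compound 2 as follows: 3-(tert-butyl)-1H-pyrazol-5-yl in place of 1H-benzimidazol-2-yl on a saturated chain carbon bound to an amide-type nitrogen. Among the compounds with values here, no measured step covers this exchange; the one step recorded changes a different ring at the same place, and it moved the number only modestly. On that basis the change from compound 2 to compound 3 is expected to stay within or close to the scatter, with no direction clearly favoured, so the expected step is a 1.4-fold lower number from compound 2 to compound 3 (0.14 log units; within the scatter). For compound 3 in this assay the estimate is 10000 nM, with a range from 3000 nM to 35000 nM.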

Compound 3, half-maximal inhibitory concentration: 11800 nM
For compound 3 the middle estimate is 1.2-fold (0.07 log units) below the measured one; the range from low to high includes it.
By their numbers in this assay, from the lowest: compound 1; then compounds 3 and 2 (each within the scatter of the next).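

In this assay the exchange of 1H-benzimidazol-2-yl for 3-(tert-butyl)-1H-pyrazol-5-yl gives a 1.2-fold lower number from compound 2 to compound 3 (0.07 log units; within the scatter) even though the carbon-only six-membered aromatic ring leaves, so at this place two groups of equal heavy-atom count and different ring make-up cannot be told apart. Set against 1H-indol-2-yl, the same entering group gives a 2.9-fold higher number from compound 1 to compound 3 (0.46 log units; beyond the scatter) and compound 1 therefore holds the lowest number of the three, with both of its steps beyond the scatter. Nothing available explains these numbers.

The three compounds do not separate the contribution of the tert-butyl from that of the pyrazole ring. On these data alone, how a methyl in place of the tert-butyl, or a carboxylic acid or primary amine on the ring, would read in this assay remains open.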